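The source may hold more compounds than are shown below. What is called first, only, known or untested is meant among the compounds shown, and "the series" means these compounds.

Going by the values given here, in a functional assay on HeLa cells (Homo sapiens) for antiproliferative activity, read by WST assay, with a stated time of 24 h (a lower number here means a stronger inhibitor, a higher number a weaker inhibitor), compound 1 `C=C[C@]1(C)CC[C@@H](C(=C)COCCOC)C[C@H]1C(=C)C`, which carries a 2-methoxyethoxy group, gives 238000 nM and stands as the higher of the two numbers so far. That makes it the weaker inhibitor of the pair. Compound 2 `C=C[C@]1(C)CC[C@@H](C(=C)CNC2CCCCCCC2)C[C@H]1C(=C)C` gives 5900 nM in this assay and sits far lower, by much more than repeat measurements usually scatter.

Compound 3 `C=C[C@]1(C)CC[C@@H](C(=C)COCCCC)C[C@H]1C(=C)C` has yet to be measured. Compared with compound 1, it has ethyl in place of methoxy on a saturated chain carbon, two bonds along the chain from an oxygen on a saturated carbon. Cut one bond further out, 2-methoxyethoxy becomes butoxy.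

Among the compounds with values here, no measured pair shows this swap directly. Within the data shown here, compound 2 at 5900 nM has a very different side chain, so it shows only that the shared core can reach far lower numbers than compound 1 does. A modest fall in this assay is expected, only slightly beyond the scatter, although no change beyond the scatter would also fit. The step expected is a 2.4-fold lower number from compound 1 to compound 3 (0.38 log units; beyond the scatter) in this estimate. For compound 3 the estimate is 100000 nM with an expected range from 30000 nM to 300000 nM as the likely span.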

Compound 3, half-maximal inhibitory concentration: 266000 nM
Estimate against measurement, compound 3: 2.7-fold (0.42 log units) below; the range from low to high includes it.
By their numbers in this assay, from the lowest: compound 2; then compounds 1 and 3 (each within the scatter of the next).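

In this assay, replacing 2-methoxyethoxy with butoxy gives a 1.1-fold higher number from compound 1 to compound 3 (0.05 log units; within the scatter) for this pair. Going by these compounds alone, this is the first direct reading at this position: 2-methoxyethoxy can become butoxy, and methoxy's hydrogen-bond acceptor can go, with no difference that stands out from the scatter of repeated measurements, so both compounds belong in the same range. No measurement shown gives a reason for this result, so the pair records what happens to the number but cannot explain it.

Because this is a single swap on one side chain, it cannot show whether the same holds for groups that differ more from these two, such as a carboxylic acid at the end of the chain or a longer chain such as hexyloxy. It also leaves open whether an oxygen placed elsewhere along the butoxy chain would behave as this swap does, or whether the same swap would read alike on a different side chain.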